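The source may hold more compounds than are shown below. What is called first, only, known or untested is meant among the compounds shown, and "the series" means these compounds.

Compound 1, `Fc1ccc(C(SCCNC2CCN(Cc3ccccc3)CC2)c2ccc(F)cc2)cc1`, is the reference point here. Within the data shown here, in an assay on membranes from Cortex for displacement of a labelled ligand from Sigma non-opioid intracellular receptor 1 (Cavia porcellus), read by scintillation counting, with a stated time of 120 min (a lower number here means a stronger inhibitor, a higher number a weaker inhibitor), compound 1 gives 3.81 nM, the lowest of the three numbers measured so far. Compound 2, `Fc1ccc(CN2CCC(NCCSC(c3ccc(F)cc3)c3ccc(F)cc3)CC2)cc1`, gives 13.3 nM in this assay, a change of a 3.5-fold higher number from compound 1 to compound 2 (0.54 log units; beyond the scatter). Compound 3, `O=C(c1cc2ccccc2[nH]1)N1CCC(NCCSC(c2ccc(F)cc2)c2ccc(F)cc2)CC1`, gives 1130 nM in this assay.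

The compound still to be measured is compound 4, `O=C(C1CC1)N1CCC(NCCSC(c2ccc(F)cc2)c2ccc(F)cc2)CC1`. It differs from compound 1 in a single place: cyclopropylcarbonyl in place of benzyl on an amine nitrogen in a ring. The group that enters carries a carbonyl directly on the ring nitrogen, which makes the two steps into compound 3 the relevant comparison, since there too a carbonyl-bearing group took the place of a benzyl or 4-fluorobenzyl on that nitrogen. Those steps were a 300-fold higher number from compound 1 to compound 3 (2.47 log units; beyond the scatter) and an 85-fold higher number from compound 2 to compound 3 (1.93 log units; beyond the scatter), both large and far beyond the scatter. Cyclopropylcarbonyl is a smaller group than (1H-indol-2-yl)carbonyl, and no measured compound shows how much of the loss seen in compound 3 comes from the carbonyl alone, so the step is expected to be large but somewhat less certain in size. The step from compound 1 to compound 4 is therefore expected to be a 240-fold higher number from compound 1 to compound 4 (2.37 log units; beyond the scatter), toward a weaker inhibitor. Compound 4 is estimated at 900 nM in this assay, with a likely range from 150 nM to 5000 nM.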

Compound 4, inhibition constant: 46.4 nM
Compound 4: middle estimate off by 19-fold (1.29 log units), on the high side; the measured number lies below the stated range.
By their numbers in this assay, from the lowest: compound 1; then compound 2; then compound 4; then compound 3.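

In this assay, a carbonyl on the ring nitrogen does not by itself bring the whole loss seen with compound 3: changing only the group on the carbonyl carbon, from 1H-indol-2-yl to cyclopropyl, gives a large gain (a 24-fold lower number from compound 3 to compound 4 (1.39 log units; beyond the scatter)). Replacing benzyl with cyclopropylcarbonyl still costs binding strength (a 12-fold higher number from compound 1 to compound 4 (1.09 log units; beyond the scatter)), and the step from the 4-fluorobenzyl compound is smaller but also beyond the scatter (a 3.5-fold higher number from compound 2 to compound 4 (0.54 log units; beyond the scatter)), so this position accepts a carbonyl-bearing group with a loss far smaller than compound 3 alone suggested. Nothing available here explains why the cyclopropyl and 1H-indol-2-yl groups on the carbonyl differ so widely.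

The compounds shown leave open how much of the remaining loss belongs to the carbonyl itself, a question that a cyclopropylmethyl group on the same ring nitrogen could help to separate. They also leave open how an open-chain group such as acetyl, or a phenyl group on the carbonyl carbon, would compare with cyclopropyl and 1H-indol-2-yl.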